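A few compounds are considered here, and "the series" means these few. Any claim that something is new, unique, unknown or untested is made for them only; others in the source may bear on it.

Of the compounds shown here, three have been read in an ADME assay on microsomes from liver (Homo sapiens) for pharmacokinetics; on this read-out lower numbers stand for slow clearance and higher numbers for fast clearance: compound 1 (`O=C(NCc1cc(-c2ccc(C(F)(F)F)nc2)ncn1)[C@@H]1CCN1S(=O)(=O)c1ccc(F)cc1`) gives 10 mL/min/kg, compound 2 (`O=C(NCc1cc(-c2ccc(C(F)(F)F)nc2)ncn1)[C@@H]1CCCN1S(=O)(=O)c1ccc(F)cc1`) gives 16 mL/min/kg and compound 3 (`O=C(NCc1cc(-c2ccc(C(F)(F)F)nc2)ncn1)[C@@H]1CCCCN1S(=O)(=O)c1ccc(F)cc1`) gives 18 mL/min/kg. Compound 2 lies within the scatter of both compound 1 and compound 3, so these numbers do not separate it from either. Compound 4 (`C[C@H]1CC[C@@H](C(=O)NCc2cc(-c3ccc(C(F)(F)F)nc3)ncn2)N1S(=O)(=O)c1ccc(F)cc1`) has methyl in place of hydrogen on a saturated ring carbon of compound 2: methyl in place of hydrogen on a saturated ring carbon. Going by the values given here, no measured step shows the effect of this change in this assay. The spread from compound 1 at 10 mL/min/kg to compound 3 at 18 mL/min/kg stays within the scatter, so a step no larger than the scatter is expected, if anything upward. The estimated change is a 1.3-fold higher number from compound 2 to compound 4 (0.10 log units; within the scatter). Compound 4 is estimated at 20 mL/min/kg, with an expected range of 11 mL/min/kg to 36 mL/min/kg.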

Compound 4, clearance: 19 mL/min/kg
Compound 4: middle estimate off by 1.1-fold (0.02 log units), on the high side, within the range that was stated.
By their numbers in this assay, from the lowest: compounds 1, 2, 3 and 4 (each within the scatter of the next).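

Methyl in place of hydrogen on this saturated ring carbon, next to the ring nitrogen, gives a 1.2-fold higher number from compound 2 to compound 4 (0.07 log units; within the scatter) in this assay, so at this position the change stays within the scatter. The earlier compounds shown here carry no group on a ring carbon here, so this is the only read of this position. Nothing measured on these compounds bears on why the step has this size. On these data alone, whether a longer chain, a hydroxyl or an amine at this carbon would also stay within the scatter remains open, as does the opposite stereochemistry of the methyl.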